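Ether side chain change: notes toward compound 3

This account rests on a few compounds, and the source may have more. Where it says the series, first, only, none or still open, it means among the compounds named here.

In a functional assay on NCI-H23 cells (Homo sapiens) for antiproliferative activity, read by sulforhodamine B assay (a lower number here means a stronger inhibitor of growth, a higher number a weaker inhibitor of growth), compound 1 (`CCC(CC)COc1cccc(O)c1C(=O)/C=C/c1ccc(O)cc1`) gives 3210 nM and compound 2 (`CC(C)COc1cccc(O)c1C(=O)/C=C/c1ccc(O)cc1`) gives 3220 nM. Among the measured compounds shown here, compound 2 therefore stands level with compound 1, the only other measured member of the series, as the two values lie within the scatter of each other.

The next analogue is compound 3 (`O=C(/C=C/c1ccc(O)cc1)c1c(O)cccc1OCCC1CCCC1`), which differs from compound 2 by cyclopentylmethyl in place of isopropyl on a saturated chain carbon bound to an oxygen on an aromatic ring. The new group carries a five-membered non-aromatic ring of carbon only, and neither measured compound has a ring at this place.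

For the measured compounds named here, one measured step bears on the change: a 1.0-fold higher number from compound 1 to compound 2 (0.00 log units; within the scatter). It falls at the same place, on a saturated chain carbon bound to an oxygen on an aromatic ring, and stays within the scatter. This single step offers no evidence on a ring-bearing group and gives no direction, so no shift beyond the scatter is expected in this assay. The estimate is a 1.1-fold lower number from compound 2 to compound 3 (0.03 log units; within the scatter), an expected step that remains within the scatter.

For compound 3 the estimated value is 3000 nM, with an expected range of 1400 nM to 6500 nM.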

Compound 3, concentration for 50% growth inhibition: 3370 nM
For compound 3 the middle estimate is 1.1-fold (0.05 log units) below the measured one; the range from low to high includes it.
By their numbers in this assay, from the lowest: compounds 1, 2 and 3 (each within the scatter of the next).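

In this assay, the move to a ring-bearing side chain reads a 1.0-fold higher number from compound 2 to compound 3 (0.02 log units; within the scatter), and the comparison with the larger open-chain group reads a 1.0-fold higher number from compound 1 to compound 3 (0.02 log units; within the scatter). The earlier pair covered only open-chain groups, whereas this place now also accepts cyclopentylmethyl, with its five-membered non-aromatic ring of carbon only, and the three compounds stay within the scatter of one another. No measurement on hand accounts for this flat reading.

All three groups at this place carry carbon only, so the compounds shown leave open whether an amine, a carboxylic acid or a hydroxyl-bearing chain on the same saturated chain carbon would move the number beyond the scatter. Also open, going by these compounds, is whether a much longer chain or a phenyl ring at this place would stay level with these three.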